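A few compounds are considered here, and "the series" means these few. Any claim that something is new, unique, unknown or untested is made for them only; others in the source may bear on it.

Compound 1, `CCCN1CCC(CNCc2cn(-c3ccc([N+](=O)[O-])cc3)nc2-c2ccc(OC(F)(F)F)cc2)CC1`, 18000 nM; compound 2, `CCCN1CCC(CNCc2cn(-c3ccc(C(F)(F)F)cc3)nc2-c2ccc(OC(F)(F)F)cc2)CC1`, 2200 nM; compound 3, `CN1CCN(CCNCc2cn(-c3ccc(C(F)(F)F)cc3)nc2-c2ccc(OC(F)(F)F)cc2)CC1`, 3000 nM, all in an ADME assay on Huh-7 cells (Homo sapiens) for cytotoxicity; on this read-out higher numbers stand for lower toxicity in this test and lower numbers for higher toxicity in this test.

Compound 2 sits at the low end of these numbers: the change from compound 1 gave an 8.2-fold lower number from compound 1 to compound 2 (0.91 log units; beyond the scatter), while the step to compound 3, a 1.4-fold higher number from compound 2 to compound 3 (0.13 log units; within the scatter), lies within the scatter. Compound 4, `CCCN1CCC(CNCc2cn(-c3ccc(C(F)(F)F)cc3)nc2-c2ccc(Cl)cc2)CC1`, differs from compound 2 by chloro in place of trifluoromethoxy on an aromatic carbon. Among the measured compounds shown here, no measured step touches this group of the shared core; both known steps change other parts of the molecule, so they say nothing direct about this exchange. With no evidence pointing either way, the step from compound 2 to compound 4 in this assay is expected to be a 1.1-fold higher number from compound 2 to compound 4 (0.06 log units; within the scatter), within the scatter. Compound 4 is therefore estimated at 2500 nM, with a range from 1000 nM to 6000 nM.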

Compound 4, half-maximal cytotoxic concentration: 1900 nM
For compound 4 the middle estimate is 1.3-fold (0.12 log units) above the measured one, within the range that was stated.
By their numbers in this assay, from the lowest: compounds 4, 2 and 3 (each within the scatter of the next); then compound 1.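

Among the compounds shown here, this is the first look at this position of the shared core: in this assay, chloro in place of trifluoromethoxy gives a 1.2-fold lower number from compound 2 to compound 4 (0.06 log units; within the scatter). So a group of 1 heavy atom replaces one of 5 heavy atoms on this aromatic carbon with no change that stands out from the scatter. Nothing available explains this result.

From the compounds shown here alone, whether other groups here, such as fluoro, methoxy or a carboxylic acid, would also stay within the scatter remains open. So does whether chloro would act the same way in compound 1 or compound 3.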